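Phenyl for Amino on a Weakly Active Core

The compounds below may be only part of what the source reports. "The series", "measured", "known", "first", "only" and "open" are said of these compounds alone.

Compound 1, `C#CCOc1ccc(-c2cc(-c3ccccc3OCC#C)nc(N)n2)cc1`, gives 28600 nM.
Compound 2, `C#CCOc1ccc(-c2cc(-c3ccc(OCC#C)c(OCC)c3)nc(N)n2)cc1`, is reported as "not active" (no number reported).

Going by the values given here, in an assay on BTI-TN-5B1-4 cells for inhibition of Amine oxidase [flavin-containing] A (Homo sapiens), read by fluorescence and Amplex Red, using microsomes, with a stated time of 30 min (a lower number here means a stronger inhibitor, a higher number a weaker inhibitor), compound 1 gives 28600 nM, and this is the only number in the set; the other entry, compound 2, is reported as "not active" (no number reported) with no number given, so nothing can be said about how far apart the two lie. Compound 3, `C#CCOc1ccc(-c2cc(-c3ccccc3OCC#C)nc(-c3ccccc3)n2)cc1`, has not been measured. It differs from compound 1 in one place: phenyl in place of amino on an aromatic carbon. Among the compounds with values here, no measured pair shows this change, so no step size can be read from the data. Compound 3 is expected to remain weak, with a 1.6-fold higher number from compound 1 to compound 3 (0.20 log units; within the scatter) estimated to be small, possibly within the scatter, and if anything toward weaker inhibition. The estimate for compound 3 in this assay is 45000 nM, with a range from 10000 nM to 200000 nM, and a real chance that only a limit is reported.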

Compound 3, half-maximal inhibitory concentration: 22000 nM
Beside the measured number, compound 3's estimate is 2.0-fold (0.31 log units) above it, within the range that was stated.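

In this assay, phenyl in place of amino on the aromatic carbon between two ring nitrogen atoms gives a 1.3-fold lower number from compound 1 to compound 3 (0.11 log units; within the scatter), so the two compounds cannot be told apart. At this position, a phenyl of 6 heavy atoms with 0 hydrogen-bond donors and 0 hydrogen-bond acceptors thus stands in for an amino group with 1 hydrogen-bond donor and 1 hydrogen-bond acceptor, with no change in inhibition that can be read beyond the scatter. Nothing available explains this outcome.

The compounds shown leave open whether the same position would tolerate a smaller group such as methyl, or a saturated amine such as morpholine. They also leave open whether a phenyl bearing a carboxylic acid or a methoxy group there would give a different number on the shared core.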